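The compounds below may be only part of what the source reports. "The series", "measured", "known", "first", "only" and "open" are said of these compounds alone.

Compound 1: `Nc1scc(CN2CCC(c3ccc(Cl)cc3)CC2)c1C(=O)c1ccc(Cl)cc1` — -24%
Compound 2: `Nc1scc(CN2CCN(c3ccc(C(F)(F)F)cc3)CC2)c1C(=O)c1cccc(C(F)(F)F)c1` — -27%
Compound 3: `Nc1scc(CN2CCN(C3CCCCCC3)CC2)c1C(=O)c1ccc(Cl)cc1` — 3.7%

Of the compounds shown here, three sharing the same core have been measured in a functional assay on CHO cells with adenosine receptor A1 (Homo sapiens) as the target, read by cAMP accumulation and immunoassay, with a stated time of 6 min, tested at 1 uM; on this read-out higher numbers stand for a weaker effect at the one concentration tested and lower numbers for a stronger effect. Compound 3, the compound with a cycloheptyl group on the ring nitrogen, stands highest of the three with 3.7%; its nearest neighbour on the numbers is compound 1 at -24%, a gap beyond the scatter, and compound 2 at -27% lies further still, also beyond the scatter. Both compounds 1 and 2 carry an aromatic group on the ring in this region, whereas compound 3 does not.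

Compound 4, `Nc1scc(CN2CCN(c3cccc(Cl)c3)CC2)c1C(=O)c1ccc(Cl)cc1`, has not yet been measured. It differs from compound 3 in one place: 3-chlorophenyl in place of cycloheptyl on an amine nitrogen in a ring. Within the data shown here, no step between measured compounds isolates this change, so the expectation rests on the whole set. Because compound 2, which also bears an aromatic group on the ring nitrogen, gives -27%, a step downward from compound 3 to compound 4 of about a number 18.7 percentage points lower from compound 3 to compound 4 (beyond the scatter) is expected. Compound 4 is therefore estimated at -15%, within a range of -35% to 10%.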

Compound 4, a percentage reported as activity, at one concentration (the size of the read-out at that concentration, not a potency): -59%
For compound 4 the middle estimate is 44 percentage points above the measured one, outside the stated range (below it).
By their numbers in this assay, from the lowest: compound 4; then compounds 2 and 1 (each within the scatter of the next); then compound 3.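

On an amine nitrogen in a ring, 3-chlorophenyl in place of cycloheptyl gives a number 62.7 percentage points lower from compound 3 to compound 4 (beyond the scatter) in this assay and this large step is beyond the scatter. Among these compounds, no earlier pair differed in one place only, so this is the first direct reading of how much the read-out can move with the group at this position, here between two groups with the same count of heavy atoms. The data shown offer no measurement that accounts for the size of this step.

Among the compounds shown here, the single pair leaves open whether the step belongs to the aromatic ring or to its chlorine, and a plain phenyl group on the same nitrogen would separate the two. Going by these compounds, how a pyridine ring or a 4-methoxyphenyl group would read at this position also remains open.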